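This account rests on a few compounds, and the source may have more. Where it says the series, first, only, none or still open, it means among the compounds named here.

In a functional assay on NCI-H460 cells (Homo sapiens) for antiproliferative activity, read by CCK-8 assay, with a stated time of 72 h (a higher number here means a weaker inhibitor, a lower number a stronger inhibitor), compound 1 (`CCC(C)n1cnc2c(NCc3ccc(C(=O)Nc4ccccc4N)cc3)nc(Cl)nc21`) gives 4940 nM and sits in the middle of the three measured numbers, with compound 2 (`Cc1ccc(Nc2nc(Cl)nc3c2ncn3Cc2ccc(C(=O)Nc3ccccc3N)cc2)cc1`) at 1590 nM on the low side and compound 3 (`Nc1ccccc1NC(=O)c1ccc(Cn2cnc3c(Nc4ccc(-c5ccccn5)cc4)nc(Cl)nc32)cc1`) at 18400 nM on the high side. Compound 4 (`CC(C)n1cnc2c(NCc3ccc(C(=O)Nc4ccccc4N)cc3)nc(Cl)nc21`) carries hydrogen in place of methyl on a saturated chain carbon, two bonds along the chain from an aromatic nitrogen so that sec-butyl becomes isopropyl. Among the compounds with values here, the only measured single-place step is a 12-fold higher number from compound 2 to compound 3 (1.06 log units; beyond the scatter) for pyridin-2-yl in place of methyl on an aromatic carbon. It lies at another place and is a much larger exchange, so it bears only weakly here. No step beyond the scatter is expected in this assay and the estimated change is only a 1.1-fold lower number from compound 1 to compound 4 (0.04 log units; within the scatter) at the middle of the range. Compound 4 is expected at 4500 nM (2000 nM to 10000 nM).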

Compound 4, half-maximal inhibitory concentration: 3410 nM
Compound 4: middle estimate off by 1.3-fold (0.12 log units), on the high side, within the range that was stated.
By their numbers in this assay, from the lowest: compound 2; then compounds 4 and 1 (each within the scatter of the next); then compound 3.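

In this assay, within the data shown here, the exchange of sec-butyl for isopropyl gives a 1.4-fold lower number from compound 1 to compound 4 (0.16 log units; within the scatter), the first reading at this position, and removing this methyl produces no step beyond the scatter. Among these compounds, the only earlier step lay at another place, so this position had no reading of its own until now. No supporting measurement bears on this result. Open, going by these compounds, is whether a longer chain, a cyclopentyl ring or a chain ending in an amine or a carboxylic acid at this position would give a step beyond the scatter.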